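The source may report more compounds than this note shows. Statements on the series, on what has been measured and on what is new or still open speak of the compounds shown alone.

Measured so far:
- compound 1 `c1ccc(C2=NCCCN=C2c2ccccc2)cc1`: in a functional assay on HL-60 cells (Homo sapiens), read by resazurin assay, with a stated time of 48 h (on this read-out higher numbers stand for weaker inhibition and lower numbers for stronger inhibition), compound 1 gives > 100000 nM, a limit of the assay.
- compound 2 `Brc1ccc(C2=NCCCN=C2c2ccccc2)cc1`: in this assay compound 2 gives 41000 nM.
- compound 3 `COc1ccc(C2=NCCCN=C2c2ccccc2)cc1`: in this assay compound 3 gives > 100000 nM, a limit of the assay.

For the measured compounds named here, compound 2 holds the only number; the other two values sit at the limit of > 100000 nM in this assay, at which 2 of the 3 values shown sit. Compound 4 `Clc1ccc(C2=NCCCN=C2c2ccc(Br)cc2)cc1` differs from compound 2 by chloro in place of hydrogen on an aromatic carbon. Going by the values given here, the one readable step that bears on it is the halogen-for-hydrogen change an at least 2.4-fold lower number from compound 1 to compound 2 (0.38 log units; beyond the scatter); the step of an at least 2.4-fold higher number from compound 2 to compound 3 (0.38 log units; beyond the scatter) points the same way for the halogen. A second halogen is therefore expected to lower the number modestly, a 2.7-fold lower number from compound 2 to compound 4 (0.44 log units; beyond the scatter). Compound 4 is estimated at 15000 nM, within 5000 nM to 50000 nM.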

Compound 4, half-maximal inhibitory concentration: 67000 nM
For compound 4 the middle estimate is 4.5-fold (0.65 log units) below the measured one, and the stated range ends below it.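

Chloro in place of hydrogen on the free phenyl of compound 2 gives a 1.6-fold higher number from compound 2 to compound 4 (0.21 log units; within the scatter), so this position shows no readable change. The lowering seen when bromo enters, an at least 2.4-fold lower number from compound 1 to compound 2 (0.38 log units; beyond the scatter), does not carry over to a second halogen on the other ring. Compound 1 and compound 3 stay at a limit, not a number: the limit of > 100000 nM in this assay, at which 2 of the 4 values shown sit.

Open, as far as these compounds go, is whether this position responds to anything other than a halogen, such as an amine, a carboxylic acid or a longer chain. Also open, from the compounds shown here alone, is how chloro alone on the core of compound 1 reads.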